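A few compounds are considered here, and "the series" means these few. Any claim that something is new, unique, unknown or untested is made for them only; others in the source may bear on it.

In a toxicity assay on HaCaT cells (Homo sapiens) for cytotoxicity, read by MTT assay (a higher number here means a weaker inhibitor, a lower number a stronger inhibitor), two compounds sharing one core have been measured so far. Compound 1 `Cc1ccc(-n2nc(-c3ccc(C(F)(F)F)cc3O)nc2-c2ccccc2O)cc1` gives 81800 nM, and compound 2 `Oc1cc(C(F)(F)F)ccc1-c1nc(-c2ccccc2O)n(-c2ccc(I)cc2)n1` gives 32100 nM, the lower of the two numbers. For the measured compounds named here, the only measured step is a 2.5-fold lower number from compound 1 to compound 2 (0.41 log units; beyond the scatter), with iodo in place of methyl on an aromatic carbon. The next compound, compound 3 `COc1cccc(-n2nc(-c3ccc(C(F)(F)F)cc3O)nc2-c2ccccc2O)c1`, has 3-methoxyphenyl in place of 4-iodophenyl on an aromatic nitrogen. Going by the values given here, no measured compound carries a methoxy group, so the one modest step is a weak guide. Compound 3 has no iodo group, and iodo went with the lower number of compound 2 at 32100 nM, so a modest move back to a higher number is expected in this assay. The expected step is a 1.8-fold higher number from compound 2 to compound 3 (0.26 log units; within the scatter). For compound 3 the estimated value is 58000 nM, with an expected range from 24000 nM to 130000 nM.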

Compound 3, half-maximal inhibitory concentration: 81100 nM
For compound 3 the middle estimate is 1.4-fold (0.15 log units) below the measured one; the range from low to high includes it.
By their numbers in this assay, from the lowest: compound 2; then compounds 3 and 1 (each within the scatter of the next).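

In this assay the new step is a 2.5-fold higher number from compound 2 to compound 3 (0.40 log units; beyond the scatter) with 3-methoxyphenyl in place of 4-iodophenyl on the aromatic nitrogen, so the lower number seen with the iodo compound does not carry over to this methoxy compound. At the same position, the comparison with the methyl compound gives a 1.0-fold lower number from compound 1 to compound 3 (0.00 log units; within the scatter) with 3-methoxyphenyl in place of 4-methylphenyl, so these two groups cannot be told apart by this measurement. Of the three groups at this position, only 4-iodophenyl stands apart, with steps beyond the scatter to both of the others.

The compounds shown leave open whether a chloro group, an amine or a carboxylic acid on this phenyl ring would share the number of the iodo compound or that of the other two. Nothing available here explains why the iodo compound differs.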